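The source may hold more compounds than are shown below. What is called first, only, known or untested is meant among the compounds shown, and "the series" means these compounds.

In a functional assay on HCT-116 cells (Homo sapiens) for inhibition, read by MTT assay, with a stated time of 72 h (on this read-out lower numbers stand for stronger inhibition of growth and higher numbers for weaker inhibition of growth), the measured compounds stand as follows:

compound 1 `Cn1ncc2cc(-c3cnccc3/C=C/C(=O)O)ccc21` gives > 30000 nM
compound 2 `Cn1ccc2cc(-c3cnccc3/C=C/C(=O)O)ccc21` gives 7260 nM
compound 3 `CNC(=O)/C=C/c1ccncc1-c1ccc2c(ccn2C)c1` gives 4450 nM

The value of compound 1 is a limit of the assay and not a number, (the limit of > 30000 nM in this assay, at which 1 of the 3 values shown sits). How the core of compound 1 differs from that of compound 2 is not broken down here.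

Between compound 2 and compound 3 one change is made, (methylamino in place of hydroxy on a carbonyl carbon), and in this assay it gives a 1.6-fold lower number from compound 2 to compound 3 (0.21 log units; within the scatter). The unmeasured compound 4 `CNC(=O)/C=C/c1ccncc1-c1ccc2c(cnn2C)c1` carries the same change on the core of compound 1, (methylamino in place of hydroxy on a carbonyl carbon); the place is the same word for word, so this is the same change rather than only the same kind.

Resting on the step from compound 2 to compound 3, the step from compound 1 to compound 4 in this assay is expected to be of about the same small size, a step that the limit leaves unreadable from compound 1 to compound 4. Since compound 1 sits at a limit, it is likely that compound 4 also returns only a limit. Compound 4 is estimated at 35000 nM, with a range expected from 12000 nM to 100000 nM.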

Compound 4, concentration for 50% growth inhibition: 3480 nM
For compound 4 the middle estimate is 10-fold (1.00 log units) above the measured one; measured number below the stated range.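

In this assay, methylamino in place of hydroxy on the carbonyl carbon gives an at least 8.6-fold lower number from compound 1 to compound 4 (0.93 log units; beyond the scatter), and the change does not carry from one core to the other at a single size: the same change on two cores in this assay, a 1.6-fold lower number (0.21 log units; within the scatter) from compound 2 to compound 3 and an at least 8.6-fold lower number (0.93 log units; beyond the scatter) from compound 1 to compound 4, at least 5.2-fold (0.72 log units) apart, beyond the scatter of two such steps

Compound 1 gives > 30000 nM, which is a limit of the assay and not a number, so the step on its core is known only as a bound: the limit of > 30000 nM in this assay, at which 1 of the 4 values shown sits.

Going by these compounds alone, with only two cores compared, these values show that the size of this step can depend on the core, but they do not show which feature of the core sets that size or how the step would behave on any third core.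

Open, going by these compounds, is whether ethylamino or an unsubstituted amino group on the same carbonyl carbon would give a step like that to compound 3 or like that to compound 4. Also open, on these data alone, is whether methoxy in that place, giving a methyl ester, would follow the methylamino group on both cores.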